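Chloro Substitution in a Paw Edema Series: Working Notes

The source may hold more compounds than are shown below. What is called first, only, known or untested is meant among the compounds shown, and "the series" means these compounds.

Compound 1 `CCOC(=O)c1c(-c2ccc(Cl)cc2)cc(-c2ccccc2)nc1N1CCCCC1` is the reference for this set. In a functional assay on the whole organism (strain Wister albino) for inhibition, with Rattus norvegicus as the target, read by paw edema, with stated times of 1 h and 4 h, at a dose of 50 mg/kg by the intraperitoneal route (a higher number here means more inhibition at the dose given (going by the name of the read-out), a lower number less inhibition), compound 1 gives 70.1%. Compound 2 `CCOC(=O)c1c(-c2ccc(Cl)c(Cl)c2)cc(-c2ccccc2)nc1N1CCCCC1` carries the change chloro in place of hydrogen on an aromatic carbon and in this assay compound 2 gives 64.7%. For the measured compounds named here, the step of a number 5.4 percentage points lower from compound 1 to compound 2 (within the scatter) is the only measured instance of this change, and its size is small.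

Compound 3 `CCOC(=O)c1c(-c2ccc(F)cc2)cc(-c2ccccc2)nc1Nc1ccccc1` has a different core; the difference between the cores of compound 3 and compound 1 is not broken down here. In this assay compound 3 gives 76%, which is within the scatter of compound 1 and beyond it relative to compound 2.

Compound 4 `CCOC(=O)c1c(-c2ccc(F)cc2)cc(-c2ccccc2)nc1Nc1ccc(Cl)cc1` is not yet measured. It differs from compound 3 by chloro in place of hydrogen on an aromatic carbon. This is the same kind of change as that from compound 1 to compound 2, but the surroundings are not identical: in compound 2 the entering chloro sits ortho to a chloro group and meta to a large group, whereas in compound 4 it sits para to a large group, with no neighbouring chloro.

Going by the values given here, since the one measured instance, a number 5.4 percentage points lower from compound 1 to compound 2 (within the scatter), stayed within the scatter, compound 4 is expected to sit near compound 3, with an estimated step of a number 4 percentage points lower from compound 3 to compound 4 (within the scatter). Among the compounds with values here, the estimate for compound 4 in this assay is therefore 72%, expected to fall between 60% and 84%, resting on the small step from compound 1 to compound 2 and on the single reading of compound 3.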

Compound 4, a percentage reported as inhibition, in the whole organism at one dose (the size of the read-out at that dose, not a potency): 78.4%
Compound 4: middle estimate off by 6.4 percentage points, on the low side; measured number inside the range.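

In this assay the change from anilino to (4-chlorophenyl)amino comes with a number 2.4 percentage points higher from compound 3 to compound 4 (within the scatter), so the added chloro leaves the reading of compound 4 within the usual spread around that of compound 3. Set beside the earlier instance, the two steps do not differ measurably: the same change on two cores in this assay, a number 5.4 percentage points lower (within the scatter) from compound 1 to compound 2 and a number 2.4 percentage points higher (within the scatter) from compound 3 to compound 4, 7.8 percentage points apart, within the scatter of two such steps. Within these two pairs, chloro in place of hydrogen on an aromatic carbon can be carried from one core to the other without a step beyond the scatter, but this does not show that the change has no effect in general, nor does it give the change a direction, since the evidence is only two pairs that also differ in the group receiving the chloro.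

The compounds shown leave open whether a methoxy group, a nitro group or an amine in place of the chloro on the (4-chlorophenyl)amino group would give a step beyond the scatter. They also leave open how the series would read with the ethyl ester exchanged for a carboxylic acid or an amide, and whether the small chloro steps would hold at other doses.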